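A few compounds are considered here, and "the series" means these few. Any claim that something is new, unique, unknown or untested is made for them only; others in the source may bear on it.

Measured compounds, all in a functional assay on KB cells (Homo sapiens) for cytotoxicity, read by MTT assay, with a stated time of 48 h; a lower number here means a stronger inhibitor, a higher number a weaker inhibitor:
- compound 1 `CCn1cc(-c2nc3ccccc3[nH]2)c(=O)c2cc(F)c(N3CCNCC3)cc21` gives 10500 nM
- compound 2 `CCn1cc(-c2nc3ccccc3[nH]2)c(=O)c2cc(F)c(N3CCNC(C)C3)c(F)c21` gives 19100 nM
- compound 3 `CCn1cc(-c2nc3ccc([N+](=O)[O-])cc3[nH]2)c(=O)c2cc(F)c(N3CCNCC3)cc21` gives 1100 nM

Compound 1 and compound 3 share a core and differ in one place only: nitro in place of hydrogen on an aromatic carbon. That single change gave a 9.5-fold lower number from compound 1 to compound 3 (0.98 log units; beyond the scatter).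

Compound 2 stands on a different core. How the core of compound 2 differs from that of compound 1 is not broken down here. In this assay compound 2 gives the highest of the three numbers; against compound 1 the gap lies within the scatter, against compound 3 it lies beyond it.

Compound 4 `CCn1cc(-c2nc3ccc([N+](=O)[O-])cc3[nH]2)c(=O)c2cc(F)c(N3CCNC(C)C3)c(F)c21` is not yet measured. It relates to compound 2 exactly as compound 3 relates to compound 1: nitro in place of hydrogen on an aromatic carbon. The place of the change is described in the same words for both pairs, so this is the same change made on the second core.

Among the measured compounds shown here, the only guide to what the change does is the single step from compound 1 to compound 3. Going by these compounds, whether the second core responds alike is unknown; one instance is a thin basis. Still, with nothing else to go on, the expectation for compound 4 in this assay is a step of about the same size as before, a 9.6-fold lower number from compound 2 to compound 4 (0.98 log units; beyond the scatter), resting on a 9.5-fold lower number from compound 1 to compound 3 (0.98 log units; beyond the scatter) applied to the value of compound 2.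

On that basis compound 4 is estimated at 2000 nM, with a likely range from 700 nM to 6000 nM.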

Compound 4, half-maximal inhibitory concentration: 2300 nM
Compound 4: middle estimate off by 1.2-fold (0.06 log units), on the low side, within the range that was stated.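

In this assay, nitro in place of hydrogen on an aromatic carbon gave an 8.3-fold lower number from compound 2 to compound 4 (0.92 log units; beyond the scatter), so the change that lowered the number on the core of compound 1 did the same on the core of compound 2. Set side by side, the two steps agree in size, and in this pair of cores the change carries over from one to the other without a measurable loss: the same change on two cores in this assay, a 9.5-fold lower number (0.98 log units; beyond the scatter) from compound 1 to compound 3 and an 8.3-fold lower number (0.92 log units; beyond the scatter) from compound 2 to compound 4, 1.1-fold (0.06 log units) apart, within the scatter of two such steps

This is agreement across two cores in a single cell assay with a single substituent, which supports carrying this one change between these two cores but gives no rule for any further core, says nothing of how the change acts, and does not show that the same holds in other cells.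

The compounds shown leave open whether the size of the step belongs to the nitro itself, since an amine, a nitrile or a carboxylic acid in the same place on either core would be needed to tell that apart from a general effect of substitution there. Also open, going by these compounds, is whether the step survives on a core with a longer chain in place of the ethyl group.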